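Ester aryl swap on the shared core: compound 4

This account rests on a few compounds, and the source may have more. Where it says the series, first, only, none or still open, it means among the compounds named here.

Measured in a functional assay on MDA-MB-231 cells (Homo sapiens) for antiproliferative activity, read by MTT assay, with a stated time of 72 h (a lower number here means a stronger inhibitor, a higher number a weaker inhibitor), so far:
compound 1 `CC1=CC[C@H]2[C@@H]1CC=C(C)[C@@H](CC[C@H]1[C@]3(C)CC[C@H](OC(=O)c4ccncc4)C(C)(C)O[C@H]3CC[C@@]1(C)O)C2(C)C` gives 19100 nM
compound 2 `CC1=CC[C@H]2[C@@H]1CC=C(C)[C@@H](CC[C@H]1[C@]3(C)CC[C@H](OC(=O)c4ccc(C)cc4)C(C)(C)O[C@H]3CC[C@@]1(C)O)C2(C)C` gives 32700 nM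
compound 3 `CC1=CC[C@H]2[C@H](CC[C@]2(C)O)C(C)(C)[C@@H]1CC[C@H]1[C@]2(C)CC[C@H](OC(=O)c3ccc(F)cc3)C(C)(C)O[C@H]2CC[C@@]1(C)O` gives 11300 nM

Compound 3 has the lowest of the three numbers, but its gap to compound 1 lies within the scatter; only the gap to compound 2 is beyond it, so compound 3 cannot be called the most active of the set. Compound 4 `CC1=CC[C@H]2[C@H](CC[C@]2(C)O)C(C)(C)[C@@H]1CC[C@H]1[C@]2(C)CC[C@H](OC(=O)c3ccc(C(F)(F)F)cc3F)C(C)(C)O[C@H]2CC[C@@]1(C)O` differs from compound 3 in a single place: 2-fluoro-4-(trifluoromethyl)phenyl in place of 4-fluorophenyl on a carbonyl carbon.

Among the compounds with values here, the only measured step that also exchanges the aryl group on the carbonyl carbon is a 1.7-fold higher number from compound 1 to compound 2 (0.23 log units; within the scatter), which stayed within the scatter. Compounds 1 and 3 differ in two places, and their values are likewise close. Within the data shown here, no step has yet moved the number beyond the scatter, so the expectation for compound 4 is a step of a 1.1-fold lower number from compound 3 to compound 4 (0.05 log units; within the scatter), that is, no shift beyond the usual scatter. Compound 4 is therefore estimated at 10000 nM in this assay, with a range from 4000 nM to 30000 nM.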

Compound 4, half-maximal inhibitory concentration: 36300 nM
Compound 4: middle estimate off by 3.6-fold (0.56 log units), on the low side, outside the stated range (above it).
By their numbers in this assay, from the lowest: compounds 3, 1, 2 and 4 (each within the scatter of the next, the first and the last beyond it).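

Replacing 4-fluorophenyl with 2-fluoro-4-(trifluoromethyl)phenyl on the carbonyl carbon gives a 3.2-fold higher number from compound 3 to compound 4 (0.51 log units; beyond the scatter) in this assay. Within the data shown here, this is the first step between compounds differing in one place that passes beyond the scatter, so the aryl group on this ester is not a neutral site on the shared core, and this larger group, with 11 heavy atoms against 7, goes with a weaker result. No measurement in hand bears on the reason for this shift.

The entering group differs from the leaving one in both its added fluorine and its trifluoromethyl, and the compounds shown do not separate these two contributions. Also open, from the compounds shown here alone, is how an aryl group carrying an amine or a carboxylic acid would read on the same carbonyl carbon.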